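The source may report more compounds than this note shows. Statements on the series, on what has been measured and on what is new or still open speak of the compounds shown alone.

Of the compounds shown here, two of one shared core have been measured so far. Compound 1 `O=C1c2c[n+]([O-])c3ccccc3c2C(=O)c2c1c1ccccc1n2CCCCN1CCCCC1` carries a piperidin-1-yl group on a saturated chain carbon, four bonds along the chain from an aromatic nitrogen, and in a toxicity assay on L02 cells (Homo sapiens) for cytotoxicity, read by MTT assay, with a stated time of 72 h (a higher number here means a weaker inhibitor, a lower number a stronger inhibitor), compound 1 gives 610 nM. Compound 2 `CN(C)CCCCn1c2c(c3ccccc31)C(=O)c1c[n+]([O-])c3ccccc3c1C2=O` keeps the same core and chain but carries a dimethylamino group there; in this assay compound 2 gives 300 nM. The single measured step is a 2.0-fold lower number from compound 1 to compound 2 (0.31 log units; beyond the scatter), so compound 2 stands as the lower of the two numbers shown, and the gap between them is beyond the scatter.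

Compound 3 `CCCCN1CCN(CCCCn2c3c(c4ccccc42)C(=O)c2c[n+]([O-])c4ccccc4c2C3=O)CC1` is not yet measured. It differs from compound 2 as follows: 4-butylpiperazin-1-yl in place of dimethylamino on a saturated chain carbon, four bonds along the chain from an aromatic nitrogen.

Going by the values given here, the only step that bears on this change is the one from compound 1 to compound 2, where a ring-bearing amine was replaced by dimethylamino and the number fell modestly. Compound 3 moves back to a ring-bearing amine, although a different and larger one, so a modest rise in the number is expected, and the step from compound 2 to compound 3 is estimated as a 1.8-fold higher number from compound 2 to compound 3 (0.26 log units; within the scatter). For compound 3 the expected value in this assay is 550 nM, with a range from 200 nM to 1500 nM.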

Compound 3, half-maximal inhibitory concentration: 5690 nM
For compound 3 the middle estimate is 10-fold (1.01 log units) below the measured one, and the stated range ends below it.
By their numbers in this assay, from the lowest: compound 2; then compound 1; then compound 3.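

Going by these compounds alone, replacing dimethylamino with 4-butylpiperazin-1-yl gives a 19-fold higher number from compound 2 to compound 3 (1.28 log units; beyond the scatter) in this assay, so the group on this chain carbon can move the number much further than the first pair of compounds suggested. A ring on the amine does not alone account for the high number: compound 1 also carries a ring-bearing amine at this place, and the comparison between the two ring-bearing amines still gives a 9.3-fold higher number from compound 1 to compound 3 (0.97 log units; beyond the scatter). Nothing available explains why the larger group gives a weaker result in this assay.

The compounds shown do not separate the part played by the butyl group from that of the piperazine ring, and a comparison with 4-methylpiperazin-1-yl or an unsubstituted piperazin-1-yl at the same place would help to tell these apart. They also leave open how morpholin-4-yl would behave at this place, and whether the large step would hold on a shorter or longer chain between the aromatic nitrogen and the amine.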